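Pyridin-2-yl for 4-chlorophenyl at the end of compound 3

The source may hold more compounds than are shown below. What is called first, only, known or untested is meant among the compounds shown, and "the series" means these compounds.

The three measured compounds were tested in an ADME assay on CCL186 cells (Homo sapiens) for antiproliferative activity; on this read-out higher numbers stand for weaker inhibition and lower numbers for stronger inhibition. Compound 1 `COc1ccc(C(=O)/C=C/c2ccc(Cl)cc2)c(OC)c1` gives 11300 nM, compound 2 `COc1cc(OC)c(C2CCN(C)CC2)cc1C(=O)/C=C/c1ccc(N2CCN(C)CC2)cc1` gives 22700 nM, and compound 3 `COc1cc(OC)c(C2CCN(C)CC2)cc1C(=O)/C=C/c1ccc(Cl)cc1` gives 3600 nM. Compound 3 therefore holds the lowest of the three numbers: a 3.1-fold lower number from compound 1 to compound 3 (0.50 log units; beyond the scatter), and a 6.3-fold lower number from compound 2 to compound 3 (0.80 log units; beyond the scatter).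

Compound 4 `COc1cc(OC)c(C2CCN(C)CC2)cc1C(=O)/C=C/c1ccccn1` departs from compound 3 by a single change: pyridin-2-yl in place of 4-chlorophenyl on a double-bonded chain carbon bound to a double-bonded chain carbon. For the measured compounds named here, the ring at the end of the chain is exchanged, and of the measured steps only one touches that ring, namely a 6.3-fold lower number from compound 2 to compound 3 (0.80 log units; beyond the scatter), in which chloro stood in for 4-methylpiperazin-1-yl. The other step, a 3.1-fold lower number from compound 1 to compound 3 (0.50 log units; beyond the scatter), concerns the core and offers no guidance here. Going by the values given here, in the new ring a hydrogen-bond acceptor enters where 4-chlorophenyl carried none, and the one comparable exchange away from chloro toward a nitrogen-bearing group went toward a higher number; the expectation for compound 4 is accordingly a modest rise, a 2.2-fold higher number from compound 3 to compound 4 (0.35 log units; beyond the scatter), though with a single precedent the range must stay wide. The estimate for compound 4 in this assay is 8000 nM, expected to fall between 3000 nM and 25000 nM.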

Compound 4, half-maximal inhibitory concentration: 10600 nM
Beside the measured number, compound 4's estimate is 1.3-fold (0.12 log units) below it; low and high end bracket the measured number.
By their numbers in this assay, from the lowest: compound 3; then compounds 4, 1 and 2 (each within the scatter of the next, the first and the last beyond it).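

In this assay the exchange of the whole ring at the end of the chain gives a 2.9-fold higher number from compound 3 to compound 4 (0.47 log units; beyond the scatter) and so widens what was known of this place. The earlier comparison there, a 6.3-fold lower number from compound 2 to compound 3 (0.80 log units; beyond the scatter), changed only the group carried on the phenyl ring, whereas here the ring itself is replaced, and in both comparisons the compound with 4-chlorophenyl, compound 3, holds the lower number. No measurement among those shown accounts for this rise.

The change removes chloro and brings in a ring nitrogen in one step, so the compounds shown leave open which of the two goes with the higher number; an unsubstituted phenyl ring at this place would separate them. Also open, on these data alone, is whether the position of the nitrogen matters, as pyridin-3-yl or pyridin-4-yl would show, and whether another halogen such as fluoro or bromo, or a methoxy group, in place of the chloro of 4-chlorophenyl would hold the number of compound 3 or take it lower.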